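This account rests on a few compounds, and the source may have more. Where it says the series, first, only, none or still open, it means among the compounds named here.

In an ADME assay on MCF-10A cells (Homo sapiens) for cytotoxicity, read by WST assay, with a stated time of 48 h (a lower number here means a stronger inhibitor, a higher number a weaker inhibitor), compound 2 `O=C(NNC(=S)Nc1cccc(Cl)c1)c1ccncc1` gives only a limit of the assay, > 300000 nM. Compound 1 `CCc1cccc(NC(=S)NNC(=O)c2ccncc2)c1`, which differs from it in a single substituent, likewise gives only a limit of the assay, > 300000 nM. Going by the values given here, the single measured step, a step that the two limits leave unreadable from compound 1 to compound 2, is therefore of unreadable size, and the whole of the evidence is the limit of > 300000 nM in this assay, at which 2 of the 2 values shown sit. Compound 3 `Cc1cccc(NC(=S)NNC(=O)c2ccncc2)c1` arises from compound 2 by methyl in place of chloro on an aromatic carbon. Among the compounds with values here, with both measured values sitting at the limit, nothing in the data shows whether exchanging chloro for methyl moves the read-out in either direction, and the expectation in this assay is no step readable beyond the scatter, most probably with the limit reported once more. Compound 3 is accordingly estimated at 500000 nM, in a range from 150000 nM to 3000000 nM. The step this estimate implies is expected to be a step that the limit leaves unreadable from compound 2 to compound 3.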

Compound 3, half-maximal inhibitory concentration: > 300000 nM
Compound 3: no number, only a limit; the forecaster's own chance of this, stated with the estimate: 85%; the middle value is on the limit's open side.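

In this assay compound 3 gives > 300000 nM, which is a limit of the assay. Going by these compounds alone, no step among compound 1, compound 2 and compound 3 can be read. The compounds shown leave open whether exchanging these substituents changes the read-out at all, since the evidence is only this: the limit of > 300000 nM in this assay, at which 3 of the 3 values shown sit.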